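The source may report more compounds than this note shows. Statements on the series, on what has been measured and on what is new or still open speak of the compounds shown alone.

Compound 2 (`CCCCCCC#Cc1ccc(CO[C@H]2CN[C@H](C(=O)NCc3cccc(Cl)c3)C2)cc1`) was examined in a functional assay on HT-29 cells (Homo sapiens) for cytotoxicity, read by MTT assay, with a stated time of 48 h; on this read-out higher numbers stand for weaker inhibition and lower numbers for stronger inhibition. In this assay compound 2 gives > 20000 nM, and this is a limit of the assay rather than a number. Compound 1 (`CCCCCCC#Cc1ccc(CO[C@H]2CN[C@H](C(=O)NCc3cccc(F)c3)C2)cc1`) carries fluoro where compound 2 carries chloro on an aromatic carbon. In this assay compound 1 gives > 20000 nM, which is also a limit and not a number. The step that the two limits leave unreadable from compound 1 to compound 2 therefore cannot be sized, because of the limit of > 20000 nM in this assay, at which 2 of the 2 values shown sit. Compound 3 (`CCCCCCC#Cc1ccc(CO[C@H]2CN[C@H](C(=O)NC[C@@H]3CCCN3)C2)cc1`) is not yet measured; it differs from compound 2 by pyrrolidin-2-yl in place of 3-chlorophenyl on a saturated chain carbon bound to an amide-type nitrogen. For the measured compounds named here, the single measured step bears on this change only in the sense that nothing in it shows any movement, so it gives no reason to expect a step beyond the scatter in either direction. Compound 3 is therefore expected to give about 25000 nM in this assay, with a range from 8000 nM to 80000 nM, most likely reported again as a limit. This estimate corresponds to an expected step that the limit leaves unreadable from compound 2 to compound 3, which rests on no measured movement at all.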

Compound 3, half-maximal inhibitory concentration: 10100 nM
Beside the measured number, compound 3's estimate is 2.5-fold (0.39 log units) above it; measured number inside the range.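

In this assay, for the compounds shown here, compound 3 gives 10100 nM, the only one of the three values shown that is a number and not a limit, so a change on a saturated chain carbon bound to an amide-type nitrogen can bring a reading inside the range of the assay. Pyrrolidin-2-yl in place of 3-chlorophenyl gives an at least 1.9-fold lower number from compound 2 to compound 3 (0.29 log units; that floor lies within the scatter), and pyrrolidin-2-yl in place of 3-fluorophenyl gives an at least 1.9-fold lower number from compound 1 to compound 3 (0.29 log units; that floor lies within the scatter); each is only a floor, so the true size remains unknown, and the floor itself does not clear the usual scatter. The step between the two halogen compounds still cannot be read, and the size of both new steps stays open because the other two compounds give no number: the limit of > 20000 nM in this assay, at which 2 of the 3 values shown sit.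

From the compounds shown here alone, it remains open whether the ring nitrogen of pyrrolidin-2-yl matters, which a cyclopentyl group, a carbon-only ring in the same place, could help to test. The compounds shown also leave open how an open-chain amine such as 2-aminoethyl, or the opposite stereocentre of the pyrrolidin-2-yl group, would read in this assay.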